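This account rests on a few compounds, and the source may have more. Where it says the series, first, only, none or still open, it means among the compounds named here.

Measured compounds in an assay on cells for inhibition of Palmitoleoyl-protein carboxylesterase NOTUM variant C330S (Homo sapiens), read by fluorescence, with a stated time of 40 min; on this read-out lower numbers stand for stronger inhibition and higher numbers for weaker inhibition:
- compound 3 `Cc1cc(C(=O)O)c(C)n1-c1cccc(Cl)c1`: 430 nM
- compound 2 `Cc1cccc(-n2c(C)cc(C(=O)O)c2C)c1`: 1500 nM
- compound 1 `Cc1cc(C(=O)O)c(C)n1-c1ccc(Cl)c(C(F)(F)F)c1`: 2100 nM

Compound 3 stands lowest of the three numbers in this assay, with compound 2 nearest and compound 1 furthest, both gaps beyond the scatter. Compound 4 `Cc1cc(C(=O)O)c(C)n1-c1cccc(C(F)(F)F)c1` differs from compound 3 by trifluoromethyl in place of chloro on an aromatic carbon. Going by the values given here, the only measured single step, a 3.5-fold lower number from compound 2 to compound 3 (0.54 log units; beyond the scatter), changed a different group at that carbon, and compound 1 carries both chloro and trifluoromethyl while differing from compound 3 in two places, so no measured step swaps chloro for trifluoromethyl. With nothing firm pointing either way, compound 4 is expected near compound 3, at 600 nM (range 250 nM to 1500 nM). The expected step of a 1.4-fold higher number from compound 3 to compound 4 (0.14 log units; within the scatter) stays within the scatter.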

Compound 4, half-maximal inhibitory concentration: 1500 nM
The estimate for compound 4 lay 2.5-fold (0.40 log units) below the measured number; the measured number falls inside the stated range.
By their numbers in this assay, from the lowest: compound 3; then compounds 2, 4 and 1 (each within the scatter of the next).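

In this assay, the position separates chloro from the other two groups: trifluoromethyl in place of chloro gives a clear loss (a 3.5-fold higher number from compound 3 to compound 4 (0.54 log units; beyond the scatter)), whereas trifluoromethyl and methyl read alike at this carbon (no change at the digits printed from compound 2 to compound 4 (within the scatter)). Among the three groups tried here, only chloro stands apart. With trifluoromethyl in place, hydrogen in place of chloro at the carbon that separates the pair also stays within the scatter (a 1.4-fold lower number from compound 1 to compound 4 (0.15 log units; within the scatter)).

No evidence here bears on why chloro differs from trifluoromethyl. Going by these compounds, whether bromo or methoxy at this carbon would read like chloro or like methyl and trifluoromethyl remains open.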